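From Fluoro to Acetamido: A Small Expected Step

The source may hold more compounds than are shown below. What is called first, only, known or untested is meant among the compounds shown, and "the series" means these compounds.

In a functional assay on QGY-7703 cells (Homo sapiens) for cytotoxicity, read by MTT assay, with a stated time of 24 h (a higher number here means a weaker inhibitor, a lower number a stronger inhibitor), compound 1 (`O=C1/C(=C/c2ccccc2F)CN(S(=O)(=O)c2ccc(F)cc2)C/C1=C\c1ccccc1F`) gives 8500 nM and compound 2 (`COc1cc(/C=C2\CN(S(=O)(=O)c3ccc(F)cc3)C/C(=C\c3cc(OC)c(OC)c(OC)c3)C2=O)cc(OC)c1OC`) gives 2220 nM as the lower and so stronger number of the two, a gap beyond the scatter. Compound 3 (`COc1cc(/C=C2\CN(S(=O)(=O)c3ccc(NC(C)=O)cc3)C/C(=C\c3cc(OC)c(OC)c(OC)c3)C2=O)cc(OC)c1OC`) carries acetamido in place of fluoro on an aromatic carbon, para to a large group (acetamido in place of fluoro on an aromatic carbon). For the measured compounds named here, no measured pair tests this change, so the expected step of a 1.1-fold higher number from compound 2 to compound 3 (0.05 log units; within the scatter) has no argued direction and is estimated to stay within the scatter. Compound 3 is expected at 2500 nM with an estimated range from 900 nM to 7000 nM in this assay as well.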

Compound 3, half-maximal inhibitory concentration: 1900 nM
Compound 3: the middle estimate sits 1.3-fold (0.12 log units) above what was measured; measured number inside the range.
By their numbers in this assay, from the lowest: compounds 3 and 2 (each within the scatter of the next); then compound 1.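

In this assay, acetamido in place of fluoro on this aromatic carbon gives a 1.2-fold lower number from compound 2 to compound 3 (0.07 log units; within the scatter). For the compounds shown here, compounds 1 and 2 both carry fluoro here, so this is the first view of the position: with the shared core of compound 2, it accepts the larger acetamido, with its hydrogen-bond donor and acceptor, with no change beyond the scatter. No evidence at hand bears on the reason for this result.

As far as these compounds go, whether an amine, a carboxylic acid or a longer chain would fare the same here remains open. So does whether acetamido would behave alike alongside the other side groups of compound 1.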